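Methoxy in place of a branched amine at the chloro-flanked ring carbon

The source may report more compounds than this note shows. Statements on the series, on what has been measured and on what is new or still open speak of the compounds shown alone.

Among the compounds with values here, the account opens with compound 1 `NC(N)=NC(=O)c1nc(Cl)c(NCc2ccc(Cl)cc2)nc1N`, which is the only member of the set with a recorded number: in an assay for inhibition of acid-sensing ion channel 3 (Homo sapiens), read by patch clamp, tested at 1 uM (a higher number here means more inhibition at the concentration tested (going by the name of the read-out), a lower number less inhibition), compound 1 gives 46%. Compound 2 `CC(C)(C)Nc1nc(N)c(C(=O)N=C(N)N)nc1Cl` shares the same core but carries a (tert-butyl)amino group where compound 1 bears a benzylamine, and in this assay compound 2 is entered as "not determined" (no result reported), so compound 2 stands nowhere on the numbers shown; no step between it and compound 1 can be stated.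

Compound 3 `COc1nc(N)c(C(=O)N=C(N)N)nc1Cl` is the unmeasured compound. It differs from compound 2 in one place: methoxy in place of (tert-butyl)amino on an aromatic carbon. Since compound 2 has no value, the size of the step from compound 2 to compound 3 in this assay cannot be counted, and only the reading of compound 1 gives a point of reference. The methoxy group is the smaller of the two, and the benzylamine of compound 1 is absent from both compounds 2 and 3, so the expectation for compound 3 is more cautious than the reading of compound 1. Compound 3 is estimated to give 22% in this assay, with a range from 0% to 50%.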

Compound 3, a percentage reported as inhibition, at one concentration (the size of the read-out at that concentration, not a potency): 21%
Beside the measured number, compound 3's estimate is 1 percentage points above it, and the stated range covers the measured number.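

Within the data shown here, compound 3 gives 21% in this assay, but compound 2 has no number there, and so no step from compound 2 to compound 3 can be read. The compounds shown leave open how methoxy compares with (tert-butyl)amino at this ring carbon. No other evidence bears on this result.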